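Two cores, one cyano-to-hydrogen change, cytotoxicity notes

The source may report more compounds than this note shows. Statements on the series, on what has been measured and on what is new or still open speak of the compounds shown alone.

Compound 1 `COc1ccc2c(c1)c(-c1cc(C(F)(F)F)c(C#N)c(-c3cn(S(=O)(=O)c4ccc(C)cc4)c4ccc(OC)cc34)n1)cn2S(=O)(=O)c1ccc(C)cc1` and compound 2 `COc1ccc2c(-c3cc(C(F)(F)F)c(C#N)c(-c4cn(S(=O)(=O)c5ccc(C)cc5)c5cc(OC)ccc45)n3)cn(S(=O)(=O)c3ccc(C)cc3)c2c1` are built from the same atoms joined differently; the difference between the two cores is not broken down here. Compound 3 `COc1ccc2c(c1)c(-c1cc(C(F)(F)F)cc(-c3cn(S(=O)(=O)c4ccc(C)cc4)c4ccc(OC)cc34)n1)cn2S(=O)(=O)c1ccc(C)cc1` is compound 1 carrying hydrogen in place of cyano on an aromatic carbon. Compound 4 `COc1ccc2c(-c3cc(C(F)(F)F)cc(-c4cn(S(=O)(=O)c5ccc(C)cc5)c5cc(OC)ccc45)n3)cn(S(=O)(=O)c3ccc(C)cc3)c2c1`, not yet measured, stands to compound 2 as compound 3 stands to compound 1, the same kind of change (hydrogen in place of cyano on an aromatic carbon), and the surroundings of the place are described in the same words for both pairs.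

In a functional assay on A549 cells (Homo sapiens) for cytotoxicity (a higher number here means a weaker inhibitor, a lower number a stronger inhibitor), compound 1 gives only a limit, > 100000 nM. In this assay compound 2 likewise gives only a limit, > 100000 nM. In this assay compound 3 also gives only a limit, > 100000 nM. The step from compound 1 to compound 3 is therefore a step that the two limits leave unreadable from compound 1 to compound 3, because the limit of > 100000 nM in this assay, at which 3 of the 3 values shown sit, leaves nothing to read off.

For compound 4 the expectation rests on compound 2, on compound 3 and on the unreadable step that the two limits leave unreadable from compound 1 to compound 3 from compound 1 to compound 3. In this assay compound 2 gives only a limit, > 100000 nM. In this assay compound 3 gives only a limit, > 100000 nM. The step from compound 2 to compound 4 in this assay is expected to be a step that the limit leaves unreadable from compound 2 to compound 4, most likely again hidden by the limit. Compound 4 is expected to give about 200000 nM in this assay, within 60000 nM to 1000000 nM, and most probably only a limit once more.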

Compound 4, half-maximal inhibitory concentration: 1700 nM
Compound 4: the middle estimate sits 120-fold (2.07 log units) above what was measured; measured number outside the range, below it.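

In this assay, on these data alone, hydrogen in place of cyano on an aromatic carbon gives an at least 58-fold lower number from compound 2 to compound 4 (1.76 log units; beyond the scatter), a large step beyond the scatter, on the core of compound 2; one end of that step is a limit, so its full size stays open. On the core of compound 1 the same change leaves compound 3 with only a limit, > 100000 nM, and that step cannot be read. The readable result therefore rests on a single pair and shows neither that the change carries from one core to the other nor that it fails to carry, because the second step is hidden: the limit of > 100000 nM in this assay, at which 3 of the 4 values shown sit.

As far as these compounds go, whether the number of compound 4, 1700 nM, depends on the loss of the nitrile alone or would also be reached with another group on the same aromatic carbon, such as an amine or a carboxylic acid, remains open. Also open, from the compounds shown here alone, are whether any change on the core of compound 1 gives a readable value, and whether the result for compound 4 extends beyond this one cell line.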